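Swapping the Ring on the Thiocarbonyl Carbon

A few compounds are considered here, and "the series" means these few. Any claim that something is new, unique, unknown or untested is made for them only; others in the source may bear on it.

Of the compounds shown here, three of one family have been tested in a functional assay on HeLa cells (Homo sapiens) for cytotoxicity, read by MTT assay, with a stated time of 72 h, tested at 3 uM; a higher number here means more inhibition of growth at the concentration tested, a lower number less inhibition of growth. Compound 1 `Cc1ccnc(/C(N)=N/NC(=S)N2CCSCC2)c1` gives 40.4%, compound 2 `N/C(=N\NC(=S)N1CCSCC1)c1ccccn1` gives 39.7%, and compound 3 `Cc1ccnc(/C(N)=N/NC(=S)N2CCN(c3ccccn3)CC2)c1` gives 42.5%. Compound 2 has the lowest of the three numbers, yet its nearest neighbour compound 1 and its furthest neighbour compound 3 both lie within the scatter of it. Among the measured compounds shown here, the only single-site step among them, a number 0.7 percentage points lower from compound 1 to compound 2 (within the scatter), also stays within the scatter.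

Compound 4 `N/C(=N\NC(=S)N1CCCC1)c1ccccn1` has not been measured. It differs from compound 2 at one site: pyrrolidin-1-yl in place of thiomorpholin-4-yl on a thiocarbonyl carbon. For the measured compounds named here, no measured step changes the ring on the thiocarbonyl carbon alone, so nothing directly informs this change. Compound 3 carries a different ring at that place than compound 2 and still sits within the scatter of it, which gives a weak hint that this site tolerates variation. The step from compound 2 to compound 4 is therefore expected to be small, a number 0.3 percentage points higher from compound 2 to compound 4 (within the scatter), with no clear direction. Compound 4 is estimated to give 40%, between 28% and 52%.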

Compound 4, percent growth inhibition at one concentration: 38.5%
Estimate against measurement, compound 4: 1.5 percentage points above; the measured number falls inside the stated range.
By their numbers in this assay, from the lowest: compounds 4, 2, 1 and 3 (each within the scatter of the next).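

Among the compounds shown here, the exchange of thiomorpholin-4-yl for pyrrolidin-1-yl on a thiocarbonyl carbon now has a direct reading in this assay (a number 1.2 percentage points lower from compound 2 to compound 4 (within the scatter)), the first for a change of this ring alone. The entering ring is five-membered with 1 hetero atom and the leaving ring six-membered with 2, yet this swap, which also removes the sulfur, gives a step that stays within the usual scatter. No measurement at hand explains the size of this step.

On these data alone, what a morpholin-4-yl ring, with oxygen in place of the sulfur, or an open-chain diethylamino group would do on the thiocarbonyl carbon remains open. Also open, as far as these compounds go, is whether the same ring swap would read alike on the core of compound 1, which carries the methyl group.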